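Working notes: phenol analogue in the ether series

This account rests on a few compounds, and the source may have more. Where it says the series, first, only, none or still open, it means among the compounds named here.

Measured so far:
compound 1 `CCCCOc1ccc(-c2nc3ncccn3c2NC(C)C)cc1` in a toxicity assay on A549 cells (Homo sapiens) for cytotoxicity, read by luminescence and CellTiter-Glo, with a stated time of 48 h (on this read-out lower numbers stand for higher toxicity in this test and higher numbers for lower toxicity in this test), gives 68000 nM.
compound 2 `CCCCOc1ccc(-c2nc3ncccn3c2N)cc1` in this assay gives > 100000 nM, which is a limit of the assay.
compound 3 `COCCOc1ccc(-c2nc3ncccn3c2NC2CCCCC2)cc1` in this assay gives > 100000 nM, again a limit of the assay.

Compound 3 therefore stands at the upper end of what this set shows: for it only a limit is reported, and the limit of > 100000 nM in this assay, at which 2 of the 3 values shown sit, shows that two of the three values shown sit there. Going by the values given here, compound 1 is the only compound with a number.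

Compound 4 `Oc1ccc(-c2nc3ncccn3c2NC2CCCCC2)cc1` differs from compound 3 by hydrogen in place of 2-methoxyethyl on an oxygen on an aromatic ring. Among the compounds with values here, the single measured step in the set, an at least 1.4-fold higher number from compound 1 to compound 2 (0.16 log units; that floor lies within the scatter), concerns the nitrogen side of the core and lies within the scatter; no measured step touches the oxygen side where the change to compound 4 sits. Within the data shown here, the one step on hand thus gives no reason to expect a shift in this assay beyond the scatter, in either direction.

Compound 4 is accordingly expected to sit close to compound 3, with a number no higher from compound 3 to compound 4 (the limit leaves the size open) as the estimated step, most probably again reported as a limit. The estimate for compound 4 in this assay is 100000 nM, with a range from 40000 nM to 300000 nM.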

Compound 4, half-maximal cytotoxic concentration: > 100000 nM
Compound 4 was reported as a limit (the forecaster's own chance of this, stated with the estimate: 65%); the middle value sits exactly at the limit.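

Compound 4 in this assay gives > 100000 nM, a limit of the assay. Compound 3 is also reported only as a limit, so no step can be read between compound 3 and compound 4. The compounds shown leave open whether hydroxy in place of 2-methoxyethoxy changes this read-out at all, and the values remain crowded at the top: the limit of > 100000 nM in this assay, at which 3 of the 4 values shown sit.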